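Replacing tert-Butyl with Chloro on the Shared Core

This account rests on a few compounds, and the source may have more. Where it says the series, first, only, none or still open, it means among the compounds named here.

Compound 1 `CC(C)(C)c1ccc(CNCCCNS(=O)(=O)c2cc(C(F)(F)F)cc(C(F)(F)F)c2)cc1` has been measured in a functional assay on MCF7 cells (Homo sapiens) for inhibition, read by MTT assay, with a stated time of 72 h (a lower number here means a stronger inhibitor of growth, a higher number a weaker inhibitor of growth), where compound 1 gives 2100 nM. Its one measured companion, compound 2 `COc1ccc(CNCCCNS(=O)(=O)c2cc(C(F)(F)F)cc(C(F)(F)F)c2)cc1`, gives 2500 nM in this assay. Of the two numbers available, compound 1 has the lowest, yet the step of a 1.2-fold higher number from compound 1 to compound 2 (0.08 log units; within the scatter) leaves the pair within the scatter, so no order between them can be read from these data.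

Compound 3 `O=S(=O)(NCCCNCc1ccc(Cl)cc1)c1cc(C(F)(F)F)cc(C(F)(F)F)c1` has not yet been measured. It differs from compound 1 in one place: chloro in place of tert-butyl on an aromatic carbon. Among the measured compounds shown here, the only measured step that bears on this change is a 1.2-fold higher number from compound 1 to compound 2 (0.08 log units; within the scatter), in which a different group entered at the same aromatic carbon and the number barely moved. With nothing else to go on, the expected step of a 1.1-fold higher number from compound 1 to compound 3 (0.06 log units; within the scatter) is therefore small, in no set direction, and not beyond the scatter. For compound 3 the estimate in this assay is 2400 nM, expected to fall between 1000 nM and 6000 nM.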

Compound 3, concentration for 50% growth inhibition: 2400 nM
For compound 3 middle estimate and measured number coincide at the digits printed, and the stated range covers the measured number.
By their numbers in this assay, from the lowest: compounds 1, 3 and 2 (each within the scatter of the next).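

With compound 3, a third group has been read at this aromatic carbon, and the numbers still do not separate: in this assay the change gives a 1.1-fold higher number from compound 1 to compound 3 (0.06 log units; within the scatter) and, against the methoxy analogue, a 1.0-fold lower number from compound 2 to compound 3 (0.02 log units; within the scatter), so all three steps among these compounds lie within the scatter. The new compound extends the comparison from tert-butyl and methoxy to a single chlorine atom, and the exchange of the 4 heavy atoms of tert-butyl for the 1 heavy atom of chloro leaves no readable difference, so across these three compounds the identity of the group at this carbon cannot be tied to any shift in the number. Nothing available accounts for this lack of separation, and no independent measurement on these compounds bears on it.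

From the compounds shown here alone, whether an amine or a carboxylic acid at this same aromatic carbon would also stay within the scatter of these three compounds remains open. So does whether the same holds for a longer chain in place of the one that carries the sulfonamide on the shared core.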